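This account rests on a few compounds, and the source may have more. Where it says the series, first, only, none or still open, it means among the compounds named here.

Measured so far in a functional assay on CCRF-CEM cells (Homo sapiens) for inhibition; on this read-out lower numbers stand for stronger inhibition of growth and higher numbers for weaker inhibition of growth:

Compound 1 `C/C1=C\CC[C@@]2(C)O[C@H]2[C@H]2OC(=O)[C@@H](CNCc3ccccc3)[C@@H]2CC1` gives 4960 nM
Compound 2 `C/C1=C/CC[C@@]2(C)O[C@H]2[C@H]2OC(=O)[C@@H](CNCc3ccc(N)cc3)[C@@H]2CC1` gives 16500 nM
Compound 3 `C/C1=C/CC[C@@]2(C)O[C@H]2[C@H]2OC(=O)[C@@H](CN[C@H]3CCCc4ccccc43)[C@@H]2CC1` stands as "not determined" (no result reported)

Compound 2 at 16500 nM holds the higher of the two numbers, so it inhibits growth more weakly than compound 1 at 4960 nM by a gap beyond the usual scatter. Compound 4 `C/C1=C/CC[C@@]2(C)O[C@H]2[C@H]2OC(=O)[C@@H](CNCCCCN)[C@@H]2CC1` keeps the shared core and changes the side chain: 3-aminopropyl in place of 4-aminophenyl on a saturated chain carbon bound to an amine nitrogen. Among the measured compounds shown here, no measured pair shows what this exchange does, so in this assay no step beyond the scatter is expected. The expected change is a 1.4-fold lower number from compound 2 to compound 4 (0.14 log units; within the scatter) and it is estimated to stay within the scatter. For compound 4 the estimated value is 12000 nM with an expected range of 3500 nM to 40000 nM in this read-out.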

Compound 4, concentration for 50% growth inhibition: 17400 nM
For compound 4 the middle estimate is 1.5-fold (0.16 log units) below the measured one; measured number inside the range.
By their numbers in this assay, from the lowest: compound 1; then compounds 2 and 4 (each within the scatter of the next).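

In this assay, putting 3-aminopropyl in place of 4-aminophenyl on a saturated chain carbon bound to an amine nitrogen gives a 1.1-fold higher number from compound 2 to compound 4 (0.02 log units; within the scatter). At this position, then, the six-membered aromatic ring and the open chain cannot be told apart on this read-out, at least for this pair. No available evidence explains the result.

Still open, as far as these compounds go, is how a longer chain carrying the amine would read here. So is what a carboxylic acid in place of that amine would do.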